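Varying the aryl group of a pyrazolopyridine kinase binder

The compounds below may be only part of what the source reports. "The series", "measured", "known", "first", "only" and "open" are said of these compounds alone.

Measured compounds:
compound 1 `CCCS(=O)(=O)Nc1ccc(F)c(C(=O)c2n[nH]c3ncc(-c4cccc(Cl)c4)cc23)c1F` — 40%
compound 2 `CCCS(=O)(=O)Nc1ccc(F)c(C(=O)c2n[nH]c3ncc(-c4cccc(F)c4)cc23)c1F` — 8.2%
compound 3 `CCCS(=O)(=O)Nc1ccc(F)c(C(=O)c2n[nH]c3ncc(-c4cccc(N(C)C)c4)cc23)c1F` — 26%

In an assay for binding affinity to dual specificity mitogen-activated protein kinase kinase 4 (Homo sapiens), read by KINOMEscan, tested at 100 nM (on this read-out higher numbers stand for a weaker effect at the one concentration tested and lower numbers for a stronger effect), compound 3 gives 26%, the second highest of the three numbers. Among the measured compounds shown here, its nearest neighbour is compound 1, and the step of a number 14 percentage points lower from compound 1 to compound 3 (beyond the scatter) is modest; the furthest is compound 2, and the step of a number 17.8 percentage points higher from compound 2 to compound 3 (beyond the scatter) is also modest, while a number 31.8 percentage points lower from compound 1 to compound 2 (beyond the scatter) is the only large step in this set.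

Compound 4 `CCCS(=O)(=O)Nc1ccc(F)c(C(=O)c2n[nH]c3ncc(-c4ccc(C)c(C)c4)cc23)c1F` differs from compound 3 by 3,4-dimethylphenyl in place of 3-(dimethylamino)phenyl on an aromatic carbon. For the measured compounds named here, none of the three measured steps exchanges a dimethylamino for two methyl groups, so no step bears on this change directly. What the steps do show is that the group on this ring moves the read-out by a modest to a large amount, without any of the three values standing apart by more than that. On this basis compound 4 is expected to give 30%, in a range from 10% to 60%. The estimated step of a number 4 percentage points higher from compound 3 to compound 4 (within the scatter) is expected to stay within the scatter of the measurement.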

Compound 4, a percentage reported as activity, at one concentration (the size of the read-out at that concentration, not a potency): 20%
Compound 4: the middle estimate sits 10 percentage points above what was measured, and the stated range covers the measured number.
By their numbers in this assay, from the lowest: compound 2; then compounds 4 and 3 (each within the scatter of the next); then compound 1.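

In this assay, the step of a number 6 percentage points lower from compound 3 to compound 4 (within the scatter) replaces 3-(dimethylamino)phenyl with 3,4-dimethylphenyl, so a ring of carbon only, with no nitrogen and no hydrogen-bond acceptor in the group, reads the same here as the dimethylamino ring. The steps of a number 11.8 percentage points higher from compound 2 to compound 4 (beyond the scatter) and a number 20 percentage points lower from compound 1 to compound 4 (beyond the scatter) place this two-methyl ring inside the span set by the 3-fluorophenyl and 3-chlorophenyl rings, so a ring with two substituents at this place still gives a read-out in the range of the single-substituent rings. Nothing given here explains these differences.

As far as these compounds go, it remains open whether a single methyl group in place of the two would read with compound 4 or move towards compound 2. From the compounds shown here alone, how a methoxy group or a carboxylic acid on this ring would read is also open.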